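Trading a Bromobenzyl for a Decyl Chain

A few compounds are considered here, and "the series" means these few. Any claim that something is new, unique, unknown or untested is made for them only; others in the source may bear on it.

Of the compounds shown here, two have been measured in a functional assay on HeLa cells (Homo sapiens) for inhibition, read by MTT assay; a higher number here means a weaker inhibitor, a lower number a stronger inhibitor. Compound 1 `CCCCCCCCCCn1cc(/C=C/C(=O)c2ccc(NC(=O)CN3CCN(c4ccccc4)CC3)cc2)nn1` gives 59100 nM in this assay. Compound 2 `CC(C)(C)OC(=O)N1CCN(CC(=O)Nc2ccc(C(=O)/C=C/c3cn(Cc4ccc(Br)cc4)nn3)cc2)CC1` gives 18900 nM in this assay, the lower of the two numbers, and its distance from compound 1 is beyond the scatter, so compound 2 stands as the stronger inhibitor of the pair.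

The next compound, compound 3 `CCCCCCCCCCn1cc(/C=C/C(=O)c2ccc(NC(=O)CN3CCN(C(=O)OC(C)(C)C)CC3)cc2)nn1`, keeps the core of compound 2 and changes one site: nonyl in place of 4-bromophenyl on a saturated chain carbon bound to an aromatic nitrogen. The decyl chain that enters is the same one carried by compound 1, while the piperazine end of compound 3 stays as in compound 2.

For the measured compounds named here, no measured pair isolates this single change, so the size of the step rests on an expectation only. Compound 1, which carries the decyl chain, gives 59100 nM, and on that basis compound 3 is expected to drift toward a weaker inhibitor, with the step from compound 2 to compound 3 estimated at a 1.9-fold higher number from compound 2 to compound 3 (0.27 log units; within the scatter). For compound 3 the estimate in this assay is 35000 nM, within a range from 12000 nM to 100000 nM.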

Compound 3, half-maximal inhibitory concentration: 30200 nM
Beside the measured number, compound 3's estimate is 1.2-fold (0.06 log units) above it; the measured number falls inside the stated range.
By their numbers in this assay, from the lowest: compounds 2, 3 and 1 (each within the scatter of the next, the first and the last beyond it).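

In this assay, the replacement of 4-bromobenzyl by decyl, on a saturated chain carbon bound to an aromatic nitrogen, gives a step that stays within the scatter (a 1.6-fold higher number from compound 2 to compound 3 (0.20 log units; within the scatter)). At this position, then, a six-membered aromatic ring bearing bromine and a straight chain with no ring are not told apart by this read-out, even though the two groups differ in their heavy atoms and in the ring itself. With the decyl chain held fixed, the exchange of phenyl for tert-butoxycarbonyl on an amine nitrogen in a ring gives a step that is also within the scatter (a 2.0-fold lower number from compound 1 to compound 3 (0.29 log units; within the scatter)), so neither single change shown here moves the number beyond it.

From the compounds shown here alone, it remains open whether a shorter chain such as hexyl, or an unsubstituted benzyl, would behave as the decyl and 4-bromobenzyl groups do at this position. Going by these compounds, it is equally open what a free secondary amine or an acetyl group would give on the ring nitrogen at the other end of the molecule.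

No other measurement bears on these results, and what lies behind them cannot be said.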